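This account rests on a few compounds, and the source may have more. Where it says the series, first, only, none or still open, it means among the compounds named here.

Measured in a functional assay on A549 cells (Homo sapiens) for inhibition, read by MTT assay, with a stated time of 48 h; on this read-out higher numbers stand for weaker inhibition and lower numbers for stronger inhibition:
- compound 1 `COc1ccc(C(c2c[nH]c3ccc(Br)cc23)c2c[nH]c3ccc(Br)cc23)c(OC)c1`: 100000 nM
- compound 2 `Brc1ccc2[nH]cc(C(c3ccc4ccccc4c3)c3c[nH]c4ccc(Br)cc34)c2c1`: 8500 nM

Compound 2 holds the lower of the two numbers, at 8500 nM. Compound 3 `Brc1ccc(C(c2c[nH]c3ccc(Br)cc23)c2c[nH]c3ccc(Br)cc23)cc1` carries 4-bromophenyl in place of naphthalen-2-yl on a saturated chain carbon bound to two aromatic carbons. Within the data shown here, the only measured step at this place is a 12-fold lower number from compound 1 to compound 2 (1.07 log units; beyond the scatter), a large one. The group in compound 3 again has one six-membered aromatic ring of carbon only, as in compound 1 at 100000 nM, so part of that step may be given back. The expected change in this assay is a 1.8-fold higher number from compound 2 to compound 3 (0.25 log units; within the scatter), towards weaker inhibition and smaller than the measured step. For compound 3 the estimated value is 15000 nM, with an expected range of 5000 nM to 50000 nM.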

Compound 3, half-maximal inhibitory concentration: 5600 nM
Compound 3: the middle estimate sits 2.7-fold (0.43 log units) above what was measured, within the range that was stated.
By their numbers in this assay, from the lowest: compounds 3 and 2 (each within the scatter of the next); then compound 1.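

At this place, on a saturated chain carbon bound to two aromatic carbons, a second six-membered aromatic ring of carbon only is not required: in this assay the exchange gives a 1.5-fold lower number from compound 2 to compound 3 (0.18 log units; within the scatter), so compound 2 and compound 3 cannot be told apart. With one such ring on both sides, the substituents alone now accompany an 18-fold lower number from compound 1 to compound 3 (1.25 log units; beyond the scatter), a large step. Nothing available gives a cause for either step. Open, on these data alone, is how plain phenyl would read here, and whether phenyl carrying a single methoxy or an amine stays with compound 1 or compound 3.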